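The compounds below may be only part of what the source reports. "The series", "measured", "known", "first", "only" and "open" are said of these compounds alone.

Measured in a functional assay on HepG2 cells (Homo sapiens) for cytotoxicity, read by MTT assay, with a stated time of 48 h; on this read-out higher numbers stand for weaker inhibition and lower numbers for stronger inhibition:
- compound 1 `CN(C)c1ccc(/C=C2/S/C(=N/c3ccccc3)N(Cc3ccncc3)C2=O)cc1`: 52600 nM
- compound 2 `COc1cc(/C=C2/S/C(=N/c3ccccc3)N(Cc3ccncc3)C2=O)ccc1O`: 28600 nM

In this assay, compound 2 at 28600 nM lies within the scatter of compound 1, so the two cannot be ranked. Compound 3 `O=C1/C(=C\c2cccc(Cl)c2)S/C(=N/c2ccccc2)N1Cc1ccncc1` keeps the shared core but carries 3-chlorophenyl in place of 4-hydroxy-3-methoxyphenyl on a double-bonded chain carbon bound to a double-bonded ring carbon. Going by the values given here, one measured step bears on this place: a 1.8-fold lower number from compound 1 to compound 2 (0.26 log units; within the scatter). Among the compounds with values here, it is the only evidence, and it involves no chlorinated group, so it offers a weak guide. Since that exchange stayed within the scatter, no change beyond the scatter is expected in this assay, and no direction can be firmly assigned. The expected change is a 1.3-fold higher number from compound 2 to compound 3 (0.12 log units; within the scatter). For compound 3 the estimated value is 38000 nM, with an expected range of 13000 nM to 100000 nM.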

Compound 3, half-maximal inhibitory concentration: 28900 nM
Compound 3: the middle estimate sits 1.3-fold (0.12 log units) above what was measured; the measured number falls inside the stated range.
By their numbers in this assay, from the lowest: compounds 2, 3 and 1 (each within the scatter of the next).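

Within this assay the 3-chlorophenyl group replaces 4-hydroxy-3-methoxyphenyl with a 1.0-fold higher number from compound 2 to compound 3 (0.00 log units; within the scatter) and replaces 4-(dimethylamino)phenyl with a 1.8-fold lower number from compound 1 to compound 3 (0.26 log units; within the scatter) on a double-bonded chain carbon bound to a double-bonded ring carbon. The earlier pair compared only groups that carry oxygen or nitrogen, whereas this result shows that a chlorine-bearing ring with no hydrogen-bond donors or acceptors also stays within the scatter at this place, so compounds 1, 2 and 3 cannot be ranked. No supporting measurement offers an explanation for this result.

The compounds shown leave open whether any group at this place can move the number beyond the scatter, such as a carboxylic acid, a primary amine or a longer chain in place of the aromatic ring. They also leave open how changes elsewhere on the shared core would read in this assay.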